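The compounds below may be only part of what the source reports. "The series", "measured", "known", "first", "only" and "open" are said of these compounds alone.

Measured compounds:
Compound 1 `O=C(NC(=S)Nc1cccc(-c2nc3ccccc3[nH]2)c1)c1ccccc1` gives only a limit in this read-out, > 10000 nM.
Compound 2 `N#Cc1ccc2[nH]c(-c3cccc(NC(=S)NC(=O)c4ccc5c(c4)OCCO5)c3)nc2c1` has no result, "not determined" (no result reported).
Compound 3 `O=C(NC(=S)Nc1cccc(-c2nc3ccccc3[nH]2)c1)c1ccc2c(c1)OCCO2` gives 500 nM.

All three share a core in which a benzimidazole-bearing aniline is joined through a thiourea to a carbonyl group; they differ only in what sits on that carbonyl carbon. Among the measured compounds shown here, in a functional assay on MDA-MB-231 cells (Homo sapiens) for inhibition, read by colorimetric assay and crystal violet staining, with a stated time of 72 h (on this read-out lower numbers stand for stronger inhibition and higher numbers for weaker inhibition), compound 3 holds the only actual number of the set; compound 1 sits at the limit of > 10000 nM in this assay, at which 1 of the 3 values shown sits, and compound 2 was not measured, so compound 3 is the one firm point of reference.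

For the measured compounds named here, the single measured step bears directly on this position: an at least 20-fold lower number from compound 1 to compound 3 (1.30 log units; beyond the scatter). Swapping the plain phenyl for the oxygen-bearing bicyclic group thus moved the result from the limit to a real number, so the group on the carbonyl carbon clearly matters here.

Compound 4 `COc1ccc(C(=O)NC(=S)Nc2cccc(-c3nc4ccccc4[nH]3)c2)cc1OC` carries the change (3,4-dimethoxyphenyl in place of 2,3-dihydro-1,4-benzodioxin-6-yl on a carbonyl carbon). Both groups bring the same count of heavy atoms, oxygens and hydrogen-bond acceptors, and differ only in whether the two oxygens are tied into a ring or left as methoxy groups. A step of the size seen from compound 1 to compound 3 is therefore not expected; rather, the estimated change is a 1.4-fold higher number from compound 3 to compound 4 (0.15 log units; within the scatter), lying within the scatter. Compound 4 is expected at 700 nM, with a range from 200 nM to 3000 nM.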

Compound 4, half-maximal inhibitory concentration: 10000 nM
Compound 4: middle estimate off by 14-fold (1.15 log units), on the low side; the whole stated range lies below it.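

Among the compounds shown, the two oxygens alone do not account for the lower number of compound 3: in this assay, 3,4-dimethoxyphenyl in place of 2,3-dihydro-1,4-benzodioxin-6-yl on a carbonyl carbon gives a 20-fold higher number from compound 3 to compound 4 (1.30 log units; beyond the scatter), even though the leaving and entering groups have the same counts of heavy atoms and hydrogen-bond acceptors. Among the compounds shown here, the earlier step showed only that the group on the carbonyl carbon matters, whereas this one shows that how the same atoms are arranged in that group also matters, with the closed ring of 2,3-dihydro-1,4-benzodioxin-6-yl going with the lower number in this pair. The remaining step, a number no higher from compound 1 to compound 4 (the limit leaves the size open), cannot be read, because compound 1 gives only a limit: the limit of > 10000 nM in this assay, at which 1 of the 4 values shown sits.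

These compounds do not show why closing the ring makes such a difference, so this pair alone cannot separate the ring itself from any other explanation. From the compounds shown here alone, it also remains open how a phenyl carrying a single methoxy group, or 1,3-benzodioxol-5-yl with its smaller oxygen-containing ring, would behave on the same carbonyl carbon.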